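A few compounds are considered here, and "the series" means these few. Any claim that something is new, unique, unknown or untested is made for them only; others in the source may bear on it.

Measured so far:
compound 1, `CN(C)CC1(c2ccc(C(F)(F)F)cc2)CCCCC1`: 268 nM
compound 2, `CNCC1(c2cccc3ccccc23)CCCCC1`: 1780 nM
compound 3, `CCN(CC)CC1(c2ccc(Cl)c(Cl)c2)CCCCC1`: < 1 nM

The three share a cyclohexane core bearing an aryl group and an aminomethyl arm; they differ in the aryl group and in the substitution on the amine nitrogen. In an assay on isolated protein for inhibition of sodium-dependent dopamine transporter (Homo sapiens) (a higher number here means a weaker inhibitor, a lower number a stronger inhibitor), compound 1 gives 268 nM and compound 2 gives 1780 nM. Compound 2 stands highest of the two numbers shown; its nearest neighbour is compound 1, and that gap lies beyond the usual scatter. For compound 3 the reading is the limit of < 1 nM in this assay, at which 1 of the 3 values shown sits, which is a limit of the assay and not a number. Among the measured compounds shown here, no two measured compounds differ in a single place, so no measured step is available.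

Compound 4, `NCC1(c2cccc3ccccc23)CCCCC1`, is not yet measured. It differs from compound 2 by hydrogen in place of methyl on an amine nitrogen; cut one bond further out, the change reads methylamino to amino, or (methylamino)methyl to aminomethyl. For the measured compounds named here, with no measured step of this kind to lean on, the step from compound 2 to compound 4 in this assay is expected to be small and, if anything, toward a higher number, at the edge of the scatter: a 1.7-fold higher number from compound 2 to compound 4 (0.23 log units; within the scatter). Compound 4 is therefore estimated at 3000 nM, within a range of 1000 nM to 10000 nM.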

Compound 4, half-maximal inhibitory concentration: 6040 nM
Estimate against measurement, compound 4: 2.0-fold (0.30 log units) below; the measured number falls inside the stated range.
By their numbers in this assay, from the lowest: compound 1; then compound 2; then compound 4. At a limit, below all of these: compound 3.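

In this assay the series now has its first step at a single place: with the aryl group and the shared core held fixed, hydrogen in place of methyl on the amine nitrogen gives a 3.4-fold higher number from compound 2 to compound 4 (0.53 log units; beyond the scatter). This shows that the methyl at this position is not silent in this assay, since its removal moves the number beyond the scatter, toward a weaker inhibitor, although the step is only modest and rests on a single pair. The values shown offer no measured property that bears on this step, and so give no grounds for explaining it.

Still open, as far as these compounds go, is whether the trend continues in the other direction on this nitrogen, with an N,N-dimethylamine, an N,N-diethylamine or a longer chain such as propyl carried by the aryl group of compound 2. Also open, from the compounds shown here alone, is whether the same change has a similar size with the aryl groups of compound 1 and compound 3, since neither compound yet has a partner that differs from it only on the nitrogen.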